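Oxime to benzoyl on the thioether chain

The source may report more compounds than this note shows. Statements on the series, on what has been measured and on what is new or still open speak of the compounds shown alone.

In a functional assay on the whole organism (strain albino) for inhibition, with Rattus norvegicus as the target, read by paw edema, with a stated time of 4 h, at a dose of 0.28 mmol/kg by the oral route (a higher number here means more inhibition at the dose given (going by the name of the read-out), a lower number less inhibition), compound 1 `CCn1c(SCC(=O)c2ccccc2)nnc1-c1cc(OC)c(OC)c(OC)c1` gives 72%. In this assay compound 2 `C=CCn1c(SC/C(=N/O)c2ccccc2)nnc1-c1cc(OC)c(OC)c(OC)c1` gives 73%; the gap to compound 1 lies within the scatter, so the two stand together. Compound 3 `C=CCn1c(SCC(=O)c2ccccc2)nnc1-c1cc(OC)c(OC)c(OC)c1` is not yet measured. It differs from compound 2 by a group of 8 heavy atoms (7 carbon, 1 oxygen; one six-membered aromatic ring of carbon only) in place of a group of 9 heavy atoms (7 carbon, 1 nitrogen, 1 oxygen; one six-membered aromatic ring of carbon only), on a saturated chain carbon bound to a sulfur. The benzoyl it takes up is the same group that compound 1 bears at that place, and compound 1 gives 72%. The expected step is a number 1 percentage points lower from compound 2 to compound 3 (within the scatter), none beyond the scatter, because compound 1 gives 72% with that group. Compound 3 is estimated at 72%, expected between 62% and 82%.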

Compound 3, a percentage reported as inhibition, in the whole organism at one dose (the size of the read-out at that dose, not a potency): 66%
Compound 3: middle estimate off by 6 percentage points, on the high side, and the stated range covers the measured number.
By their numbers in this assay, from the lowest: compounds 3, 1 and 2 (each within the scatter of the next).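

In this assay the benzoyl and the group it replaces on a saturated chain carbon bound to a sulfur stand together, with a number 7 percentage points lower from compound 2 to compound 3 (within the scatter). With the benzoyl held fixed, vinyl in place of methyl on a saturated chain carbon bound to an aromatic nitrogen also stays within the scatter, with a number 6 percentage points lower from compound 1 to compound 3 (within the scatter). Nothing available explains why these numbers lie together.

Open, as far as these compounds go, is whether an amine or a carboxylic acid at the sulfur-side chain carbon would give a step beyond the scatter. Also open, from the compounds shown here alone, is whether a longer chain at the nitrogen-side chain carbon would do so.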